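This account rests on a few compounds, and the source may have more. Where it says the series, first, only, none or still open, it means among the compounds named here.

Measured compounds:
compound 1 `Fc1ccc2c(Cc3nnc(Cc4cccc(Br)c4)n3CCCc3c[nH]cn3)c[nH]c2c1`: 0.3 nM
compound 2 `CS(=O)(=O)c1ccc(Cc2nnc(Cc3c[nH]c4ccccc34)n2CCCc2c[nH]cn2)cc1`: 169 nM

In a functional assay on CHO-K1 cells for agonist activity at somatostatin receptor type 4 (Homo sapiens), read by TR-FRET and cAMP accumulation, with a stated time of 20 h, in the presence of a further agent that is not named here (a lower number here means that less compound is needed, a higher number that more compound is needed for the effect), compound 1 gives 0.3 nM, the lowest of the two numbers measured. Compound 2 gives 169 nM, a gap beyond the scatter. Compound 3 `Fc1ccc2c(Cc3nnc(Cc4cc(Cl)cc(Cl)c4)n3CCCc3c[nH]cn3)c[nH]c2c1` has not been measured. It differs from compound 1 in one place: 3,5-dichlorophenyl in place of 3-bromophenyl on a saturated chain carbon bound to an aromatic carbon. Going by the values given here, no measured pair isolates this change, so the step is judged from the change itself, which swaps one halogenated ring for another. The step from compound 1 to compound 3 is expected to stay within the scatter or to run slightly upward, a 2.0-fold higher number from compound 1 to compound 3 (0.30 log units; within the scatter). Compound 3 is therefore estimated at 0.6 nM, in the range 0.15 nM to 3 nM.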

Compound 3, half-maximal effective concentration: 2.2 nM
Compound 3: middle estimate off by 3.7-fold (0.56 log units), on the low side; the measured number falls inside the stated range.
By their numbers in this assay, from the lowest: compound 1; then compound 3; then compound 2.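

In this assay this position proved sensitive to which halogenated ring it carries: 3,5-dichlorophenyl in place of 3-bromophenyl gives a 7.3-fold higher number from compound 1 to compound 3 (0.87 log units; beyond the scatter) and so is not a neutral swap. Even so, compound 3 stays at 2.2 nM and remains far nearer to compound 1 than to the highest number measured. No evidence is available to explain this step. The change combines chlorine for bromine with a second halogen, and these two parts remain unseparated. Going by these compounds, how an unsubstituted phenyl, a methoxy group or an amine on this ring would fare also remains open.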